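A few compounds are considered here, and "the series" means these few. Any claim that something is new, unique, unknown or untested is made for them only; others in the source may bear on it.

In a functional assay on QGY cells (Homo sapiens) for cytotoxicity, read by MTT assay, with a stated time of 48 h (a lower number here means a stronger inhibitor, a higher number a weaker inhibitor), compound 1 (`COc1cc([C@@H]2C[C@]2(CO)C(=O)Nc2ccccc2Cl)cc(OC)c1OC`) gives 15700 nM as one of three measured numbers. The other two come from compound 2 (`COc1cc([C@@H]2C[C@]2(CO)C(=O)NCc2ccc(C)cc2)cc(OC)c1OC`) at 25100 nM and compound 3 (`CCOC(=O)[C@]1(C(=O)Nc2ccccc2Cl)C[C@H]1c1cc(OC)c(OC)c(OC)c1`) at 28000 nM in the same test. Compound 1 is not clearly separated from either neighbour. Putting 4-methylbenzyl in place of 2-chlorophenyl on an amide-type nitrogen gives a 1.6-fold higher number from compound 1 to compound 2 (0.20 log units; within the scatter) and no more. Putting ethoxycarbonyl in place of hydroxymethyl on a saturated ring carbon gives a 1.8-fold higher number from compound 1 to compound 3 (0.25 log units; within the scatter) and no more.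

Compound 4 (`COc1cc([C@H]2C[C@@]2(CO)C(=O)Nc2ccccc2Cl)cc(OC)c1OC`) has yet to be measured. Its relation to compound 1 is this: the two compounds have the same atoms and bonds and differ only in configuration as drawn: 2 of 2 stereo elements differ (all stereocentres are inverted: mirror images); a stereocentre at a saturated ring carbon is drawn S in compound 1 and R in compound 4; a stereocentre at a saturated ring carbon is drawn S in compound 1 and R in compound 4 so the two are mirror images. Neither measured step involves a change of configuration, so the data offer only indirect guidance, and the range below is kept wide for that reason. Both measured steps stayed small, so no step beyond the scatter is expected in this assay here. The expected change is a 1.1-fold higher number from compound 1 to compound 4 (0.06 log units; within the scatter) in this estimate. The estimated value for compound 4 is 18000 nM with an expected range from 7000 nM to 50000 nM in this test.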

Compound 4, half-maximal inhibitory concentration: > 100000 nM
Compound 4: a limit, no number (the forecaster's own chance of this, stated with the estimate: 15%); middle value at least 5.5-fold (0.74 log units) from the limit.
By their numbers in this assay, from the lowest: compounds 1, 2 and 3 (each within the scatter of the next). At a limit, above all of these: compound 4.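

In this assay, the two earlier steps from compound 1 both stayed within the scatter, and neither showed any clear sensitivity to the groups that were changed. Inverting both stereocentres gives an at least 6.3-fold higher number from compound 1 to compound 4 (0.80 log units; beyond the scatter), the first step here beyond the scatter, and the cause can lie only in the spatial arrangement of the molecule, with no group added or lost: the fact that compounds 1 and 4 differ only in the configuration as drawn. From the compounds shown here alone, the reading for compound 4 is a limit and not a number, so the full size of this step stays unknown: the limit of > 100000 nM in this assay, at which 1 of the 4 values shown sits.

Which of the two stereocentres matters more remains open, as does whether the same inversion would have a similar effect on compound 2 or compound 3. Also open, going by these compounds, is how a carboxylic acid in place of the hydroxymethyl would read in this assay in the configuration of compound 1.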